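A few compounds are considered here, and "the series" means these few. Any claim that something is new, unique, unknown or untested is made for them only; others in the source may bear on it.

In a functional assay on CCRF-CEM cells (Homo sapiens) for inhibition, read by cell counting, with a stated time of 3 days (a higher number here means a weaker inhibitor, a lower number a stronger inhibitor), compound 1 `C=C(Br)C(=O)Nc1cccc(-c2cn3nc(-c4ccc(F)cc4)sc3n2)c1` gives 830 nM. Compound 2 `C=C(Br)C(=O)Nc1cccc(-c2cn3nc(-c4ccc(Cl)cc4)sc3n2)c1` gives 3200 nM in this assay, and the change fluoro in place of chloro on an aromatic carbon made a 3.9-fold lower number from compound 2 to compound 1 (0.59 log units; beyond the scatter). Compound 3 `Nc1cccc(-c2cn3nc(-c4ccc(Cl)cc4)sc3n2)c1` gives only a limit of the assay in this assay, namely > 250000 nM, so that the limit of > 250000 nM in this assay, at which 1 of the 3 values shown sits, holds for it. From compound 2 the change hydrogen in place of (1-bromoethenyl)carbonyl on a nitrogen on an aromatic ring gave an at least 78-fold higher number from compound 2 to compound 3 (1.89 log units; beyond the scatter). Compound 4 `Nc1cccc(-c2cn3nc(-c4ccc(F)cc4)sc3n2)c1` has not yet been measured; it differs from compound 3 by fluoro in place of chloro on an aromatic carbon, the same change that was made from compound 2 to compound 1, here on a core that differs from the core of compound 2 by hydrogen in place of (1-bromoethenyl)carbonyl on a nitrogen on an aromatic ring. Because the step of an at least 78-fold higher number from compound 2 to compound 3 (1.89 log units; beyond the scatter) left no measurable inhibition, compound 4 is expected to remain at the limit, an expected step of a number no higher from compound 3 to compound 4 (the limit leaves the size open). The estimate for compound 4 is 250000 nM, between 60000 nM and 250000 nM.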

Compound 4, half-maximal inhibitory concentration: >= 250000 nM
Compound 4 gave a limit, no number; the forecaster's own chance of this, stated with the estimate: 85%; the middle value sits exactly at the limit.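

In this assay, hydrogen in place of (1-bromoethenyl)carbonyl on the nitrogen gave an at least 300-fold higher number from compound 1 to compound 4 (2.47 log units; beyond the scatter), so the loss seen on the chloro core also appears on the fluoro core. Set beside the earlier step, the change points the same way on both cores, but its size cannot be compared: the same change on two cores in this assay, an at least 78-fold higher number (1.89 log units; beyond the scatter) from compound 2 to compound 3 and an at least 300-fold higher number (2.47 log units; beyond the scatter) from compound 1 to compound 4; the limit leaves it open whether they differ Compound 3 and compound 4 both stand at limits of the assay, so the step between them cannot be read, and what fluoro in place of chloro does without the (1-bromoethenyl)carbonyl group stays unknown.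

The compounds shown leave open whether the bromine is needed or whether an acetyl or a plain propenoyl group on the nitrogen would serve. They also leave open how a 4-methoxyphenyl would compare with the 4-fluorophenyl and 4-chlorophenyl groups.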